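A few compounds are considered here, and "the series" means these few. Any claim that something is new, unique, unknown or untested is made for them only; others in the source may bear on it.

Measured so far:
Compound 1, `Nc1ncn(C/C=C2\OC(=O)C(OCc3ccccc3)=C2OCc2ccccc2)c(=O)n1` — 3490 nM
Compound 2, `NC1(CCn2cc(F)c(=O)[nH]c2=O)OC(=O)C(OCc2ccccc2)=C1OCc1ccccc1` — 20900 nM

Within the data shown here, in a functional assay on MCF7 cells (Homo sapiens) for inhibition, read by MTT assay, with a stated time of 72 h (on this read-out higher numbers stand for weaker inhibition and lower numbers for stronger inhibition), compound 2 holds the highest number of the two measured; its only neighbour, compound 1, sits clearly lower, beyond the usual scatter. Compound 3, `NC1(CCn2c(=O)[nH]c(=O)[nH]c2=O)OC(=O)C(OCc2ccccc2)=C1OCc1ccccc1`, has not yet been measured. It differs from compound 2 in one place: a group of 9 heavy atoms (3 carbon, 3 nitrogen, 3 oxygen; one six-membered aromatic ring with 3 hetero atoms) in place of a group of 9 heavy atoms (4 carbon, 2 nitrogen, 2 oxygen, 1 fluorine; one six-membered aromatic ring with 2 hetero atoms), on a saturated chain carbon, two bonds along the chain from a saturated ring carbon. Among the measured compounds shown here, no measured pair shows this particular change, so there is nothing in hand to read its effect from; the two values known so far show only that compound 1 lies well below compound 2. With the shared core kept and one ring exchanged for another, the step from compound 2 to compound 3 is expected to be small, without a clear direction and probably within the scatter: a 1.4-fold higher number from compound 2 to compound 3 (0.16 log units; within the scatter). Compound 3 is accordingly estimated at 30000 nM, within a range from 8000 nM to 100000 nM.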

Compound 3, half-maximal inhibitory concentration: 84900 nM
Beside the measured number, compound 3's estimate is 2.8-fold (0.45 log units) below it, within the range that was stated.
By their numbers in this assay, from the lowest: compound 1; then compound 2; then compound 3.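

In this assay, the group on the saturated chain carbon, two bonds along the chain from a saturated ring carbon, turns out to matter: replacing the fluorine-bearing ring with one six-membered aromatic ring with 3 hetero atoms gives a 4.1-fold higher number from compound 2 to compound 3 (0.61 log units; beyond the scatter) and so weaker inhibition. Both groups have 9 heavy atoms, so this shift comes with a change in which atoms are present and not in their number. No measurement here explains the shift.

The exchange alters several things at once, including the fluorine, a ring atom and the hydrogen-bond donors and acceptors, so these compounds cannot show which of them counts. Also open, from the compounds shown here alone, is how this position would respond to a ring carrying a chlorine or a methyl group in place of the fluorine, or to a longer chain.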